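The source may hold more compounds than are shown below. What is called first, only, known or untested is meant among the compounds shown, and "the series" means these compounds.

In a functional assay on HeLa cells (Homo sapiens) for cytotoxicity, read by MTT assay (a higher number here means a weaker inhibitor, a lower number a stronger inhibitor), compound 1 (`CCCCCCCCCC(O)CNC(C)=O`) is reported as "not active" (no number reported). Compound 2 (`CCCCCCCCCC(O)CN`) gives 4360 nM, and compound 3 (`COC(=O)CCCCCCCCC(O)CN`) gives 3590 nM. Going by the values given here, compound 3 thus holds one of only two numbers, and the two lie within the scatter of each other. The unmeasured compound 4 (`NCC(O)CCCCCCCCC(=O)O`) differs from compound 3 by hydrogen in place of methyl on an oxygen next to a carbonyl group, which turns methoxycarbonyl to carboxy. Among the compounds with values here, one measured step touches the same end of the chain: a 1.2-fold lower number from compound 2 to compound 3 (0.08 log units; within the scatter). Within the data shown here, that step replaces methyl with methoxycarbonyl, and no measured pair includes a carboxy compound, so it offers only weak guidance. Compound 1, reported as "not active" (no number reported), shows that a close relative can yield no number at all. A moderate move toward a higher number in this assay is therefore expected, with a real chance of no number being reported, and the expected step is a 3.3-fold higher number from compound 3 to compound 4 (0.52 log units; beyond the scatter). For compound 4, the estimated value is 12000 nM, with an expected range from 3500 nM to 60000 nM.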

Compound 4, half-maximal inhibitory concentration: "not active" (no number reported)
Compound 4: no number reported; the estimate stays without a comparison.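

In this assay, going by these compounds alone, compound 4 gives "not active" (no number reported), so no step from compound 3 to compound 4 can be read. The compounds shown leave open how far carboxy in place of methoxycarbonyl shifts the number. Nothing shown accounts for this result.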